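Two benzothiazolyl anilides and a third at the assay ceiling

This account rests on a few compounds, and the source may have more. Where it says the series, first, only, none or still open, it means among the compounds named here.

Compound 1 `O=C(O)/C=C/C(=O)Nc1cccc(-c2nc3ccccc3s2)c1` gives > 25000 nM in an ADME assay on HEK293 cells (Homo sapiens) for inhibition, with a stated time of 72 h (a higher number here means that more compound is needed for the effect, a lower number that less compound is needed), a limit of the assay.
Compound 2 `O=C(Nc1cccc(-c2nc3ccccc3s2)c1)c1cnccc1Cl` gives > 25000 nM in this assay, again a limit.

Compound 1 stands only at a limit in this assay, and nothing else about it is known here. The step that the two limits leave unreadable from compound 1 to compound 2 therefore cannot be read; both values sit at the ceiling described by the limit of > 25000 nM in this assay, at which 2 of the 2 values shown sit. Compound 3 `O=C(Nc1cccc(-c2nc3ccccc3s2)c1)c1ccnc(Cl)c1` has not been measured. Among the compounds with values here, it differs from compound 1 by 2-chloropyridin-4-yl in place of 2-carboxyethenyl on a carbonyl carbon, a change that is the only measured precedent, and that precedent gives no readable size or direction. Compound 3 is expected to remain at or beyond the same ceiling, with an estimated 30000 nM and a range from 10000 nM to 100000 nM. The step that the limit leaves unreadable from compound 1 to compound 3 expected from this estimate is no step beyond the scatter, and most likely only a limit will be reported again.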

Compound 3, half-maximal effective concentration: > 25000 nM
Compound 3: a limit, no number; the forecaster's own chance of this, stated with the estimate: 80%; the middle value is on the limit's open side.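

Compound 3 gives > 25000 nM in this assay, again a limit of the assay. Its steps from compound 1 and compound 2 therefore cannot be read. The compounds shown leave open whether the groups on the carbonyl carbon differ at all, with every value at one ceiling: the limit of > 25000 nM in this assay, at which 3 of the 3 values shown sit.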